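A few compounds are considered here, and "the series" means these few. Any claim that something is new, unique, unknown or untested is made for them only; others in the source may bear on it.

Measured compounds and values:

- Compound 1, `COc1cc(/C=C/C(=O)c2ccc([Si](C)(C)C)cc2)ccc1O`: 52800 nM
- Compound 2, `COc1cc(/C=C/C(=O)c2cc(F)c(F)c(F)c2)ccc1O`: 53200 nM
- Compound 3, `COc1cc(/C=C/C(=O)c2c(O)c3ccccc3oc2=O)ccc1O[Si](C)(C)C(C)(C)C`: 45500 nM

All three compounds were measured in a functional assay; on this read-out lower numbers stand for stronger inhibition and higher numbers for weaker inhibition. Compound 1 gives 52800 nM in this assay. Compound 2 gives 53200 nM. Compound 3 gives 45500 nM. The three numbers sit close together; the number for compound 3 differs from that of compound 1 and from that of compound 2 by less than the usual scatter, so no ranking among them can be drawn from these data. Among the measured compounds shown here, no two of the measured compounds differ in a single place, so no step with a known size is available.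

The next compound, compound 4, `COc1cc(/C=C/C(=O)c2c(O)c3ccccc3oc2=O)ccc1O`, is the free-phenol counterpart of compound 3. The change is a hydrogen atom in place of a group of 7 heavy atoms (6 carbon, 1 silicon; no ring), on an oxygen on an aromatic ring. It is the only structural variation with a measured neighbour, and its effect on this assay is not known from the present data. Given that all three measured compounds, including compound 3 with 45500 nM, fall in the same narrow band, the expected step from compound 3 to compound 4 is small: a 1.3-fold lower number from compound 3 to compound 4 (0.11 log units; within the scatter), not beyond the scatter in either direction. Compound 4 is therefore estimated at 35000 nM, in a range from 12000 nM to 100000 nM.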

Compound 4, half-maximal inhibitory concentration: 52500 nM
The estimate for compound 4 lay 1.5-fold (0.18 log units) below the measured number; the range from low to high includes it.
By their numbers in this assay, from the lowest: compounds 3, 4, 1 and 2 (each within the scatter of the next).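

In this assay, a hydrogen atom in place of the group of 7 heavy atoms (6 carbon, 1 silicon; no ring), on an oxygen on an aromatic ring, gives a 1.2-fold higher number from compound 3 to compound 4 (0.06 log units; within the scatter). Among the compounds shown here, this is the only step of known size, and it lies within the scatter. At this oxygen, the read-out therefore does not separate the free phenol from the group of 7 heavy atoms, so this large change in heavy-atom count has no resolved effect on the number. No independent data bear on why the step is this small.

On these data alone, it remains open whether a different substituent on this oxygen, such as a methyl group or a longer chain ending in a carboxylic acid or an amine, would move the number beyond the scatter. As far as these compounds go, it is also open whether an amine or a carboxylic acid placed elsewhere on the shared core would lift any compound out of the narrow band in this assay that these four compounds occupy.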